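Quinolin-3-yl in place of indolyl on the enamine nitrogen

The source may hold more compounds than are shown below. What is called first, only, known or untested is meant among the compounds shown, and "the series" means these compounds.

The shared core of compound 1 `O=C(/C=C\Nc1ccc2cc[nH]c2c1)c1nc(-c2ccc(C(F)(F)F)cc2)n2ccccc12` carries a trifluoromethylphenyl group and an enamine nitrogen bearing the 1H-indol-6-yl group. In a functional assay on A549 cells (Homo sapiens) for cytotoxicity, read by MTT assay, with a stated time of 48 h (a higher number here means a weaker inhibitor, a lower number a stronger inhibitor), compound 1 gives > 30000 nM, which is a limit of the assay rather than a number. Compound 1 thus stands at the limit of > 30000 nM in this assay, at which 1 of the 3 values shown sits. Two further members of the series, compound 2 `COc1ccc(-c2nc(C(=O)/C=C\Nc3ccc(Cl)cc3)c3ccccn23)cc1` and compound 3 `COc1ccc(N/C=C\C(=O)c2nc(-c3ccc(OC)cc3)n3ccccc23)cc1`, carry methoxyphenyl groups; in this assay compound 2 gives "not determined" (no result reported) and compound 3 gives "not determined" (no result reported), so no number exists for either.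

Compound 4 `O=C(/C=C\Nc1cnc2ccccc2c1)c1nc(-c2ccc(C(F)(F)F)cc2)n2ccccc12` differs from compound 1 by quinolin-3-yl in place of 1H-indol-6-yl on an amine nitrogen. Among the measured compounds shown here, no step between two measured compounds is available to size this change, and the single anchor is a limit. The expected step is a step that the limit leaves unreadable from compound 1 to compound 4, not beyond the usual scatter. Compound 4 is estimated at 40000 nM in this assay, within 8000 nM to 200000 nM, with a fair chance that only a limit is reported again.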

Compound 4, half-maximal inhibitory concentration: > 30000 nM
Compound 4: no number, only a limit; the forecaster's own chance of this, stated with the estimate: 70%; the middle value does not contradict the limit.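

Compound 1 and compound 4 each stand only as a limit in this assay, so no step can be read for quinolin-3-yl in place of 1H-indol-6-yl: the limit of > 30000 nM in this assay, at which 2 of the 4 values shown sit.

The compounds shown leave open whether any group on that amine nitrogen gives a readable number.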